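The source may hold more compounds than are shown below. What is called first, only, known or untested is meant among the compounds shown, and "the series" means these compounds.

Values measured in a functional assay on L1210 cells (Mus musculus) for cytotoxicity, read by MTT assay, with a stated time of 24 h (a higher number here means a weaker inhibitor, a lower number a stronger inhibitor), for the three compounds so far:

- compound 1 `COc1cc(C(=O)/C=C/c2ccc3ccccc3c2)ccc1O` gives 54000 nM
- compound 2 `COc1cc(C(=O)/C=C/c2ccc(Cl)c(Cl)c2)cc(OC)c1OC` gives 44000 nM
- compound 3 `COc1cc(/C=C/C(=O)c2cc(OC)c(OC)c(OC)c2)ccc1O` gives > 100000 nM

Compound 3 reads > 100000 nM as a limit of the assay and not as a number. Compound 2 at 44000 nM and compound 1 at 54000 nM lie within the usual scatter of each other. Compound 4 `COc1cc(C(=O)/C=C/c2ccc(Cl)cc2Cl)cc(OC)c1OC` has the same atoms as compound 2, joined differently, with 2,4-dichlorophenyl in place of 3,4-dichlorophenyl on a double-bonded chain carbon bound to a double-bonded chain carbon. Within the data shown here, no measured pair here shows a change of this kind, so no step beyond the scatter is expected in either direction in this assay. The expected step of a 1.1-fold lower number from compound 2 to compound 4 (0.04 log units; within the scatter) stays small. For compound 4 the estimate is 40000 nM with an expected range of 18000 nM to 90000 nM in this assay.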

Compound 4, half-maximal inhibitory concentration: 52500 nM
Estimate against measurement, compound 4: 1.3-fold (0.12 log units) below; measured number inside the range.
By their numbers in this assay, from the lowest: compounds 2, 4 and 1 (each within the scatter of the next). At a limit, above all of these: compound 3.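

Swapping 3,4-dichlorophenyl for 2,4-dichlorophenyl on a double-bonded chain carbon bound to a double-bonded chain carbon gives a 1.2-fold higher number from compound 2 to compound 4 (0.08 log units; within the scatter) in this assay. Among these compounds, this is the first comparison here of compounds that differ in one place, and it shows that rearranging the two chlorines on this ring does not separate the two compounds in this assay. No measurement shown here bears on why this is so.

Still open, going by these compounds, is whether a different group at this place, such as an amine or a carboxylic acid on the ring in place of a chlorine, would change the number beyond the scatter.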